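Notes on compound 4 in the shared series

The source may report more compounds than this note shows. Statements on the series, on what has been measured and on what is new or still open speak of the compounds shown alone.

Compound 3 `CS/C(=N\O)c1ccc(Sc2cc(F)cc(C3CCOCC3)c2)cc1` gives 190 nM in a functional assay (blood) for inhibition, with Homo sapiens as the target (a higher number here means a weaker inhibitor, a lower number a stronger inhibitor), the lowest of the three numbers in hand. Compound 1 `C/C(=N\OCCSc1nnc(C)s1)c1ccc(Sc2cc(F)cc(C3CCOCC3)c2)cc1` gives 230 nM in this assay, within the scatter of compound 3, so no order between the two can be read. Compound 2 `COC(=O)C(C)(C)CO/N=C(\C)c1ccc(Sc2cc(F)cc(C3CCOCC3)c2)cc1` gives 420 nM in this assay, beyond the scatter from compound 3. Within the data shown here, the only measured step, a 1.8-fold higher number from compound 1 to compound 2 (0.26 log units; within the scatter), lies within the scatter and concerns a group on a saturated chain carbon bound to an oxygen, a different place from the change now considered.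

Compound 4 `C/C(=N\O)c1ccc(Sc2cc(F)cc(C3CCOCC3)c2)cc1` differs from compound 3 as follows: methyl in place of methylsulfanyl on a carbon with a double bond to nitrogen. Among the measured compounds shown here, no measured step in this set touches the carbon with a double bond to nitrogen, so nothing here bears directly on the change. Compound 1 carries a methyl on that carbon together with a substituent on the oxygen and gives 230 nM, which sits within the scatter of compound 3. The expected step is a 1.3-fold higher number from compound 3 to compound 4 (0.12 log units; within the scatter), none beyond the scatter, because compound 1 gives 230 nM. Compound 4 is therefore estimated at 250 nM, with a range of 100 nM to 650 nM.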

Compound 4, half-maximal inhibitory concentration: 80 nM
Compound 4: the middle estimate sits 3.1-fold (0.49 log units) above what was measured; the whole stated range lies above it.
By their numbers in this assay, from the lowest: compound 4; then compounds 3, 1 and 2 (each within the scatter of the next, the first and the last beyond it).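

In this assay, among these compounds, the carbon with a double bond to nitrogen proves sensitive to substitution for the first time in this set: methyl in place of methylsulfanyl gives a 2.4-fold lower number from compound 3 to compound 4 (0.38 log units; beyond the scatter) and makes compound 4 the strongest inhibitor of the four. The oxygen also proves to be a position that responds, which the earlier step between two substituted compounds could not show, since a 1.8-fold higher number from compound 1 to compound 2 (0.26 log units; within the scatter) left those two unresolved. Hydrogen in place of 2-(methoxycarbonyl)-2-methylpropyl on that oxygen gives a 5.3-fold lower number from compound 2 to compound 4 (0.72 log units; beyond the scatter) and hydrogen in place of 2-((5-methyl-1,3,4-thiadiazol-2-yl)sulfanyl)ethyl gives a 2.9-fold lower number from compound 1 to compound 4 (0.46 log units; beyond the scatter), so both substituents sit on the weaker side of hydrogen, with no compound here going against that.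

Still open, as far as these compounds go, is whether an ethyl or an amine on the carbon with a double bond to nitrogen would match methyl, and whether a small methyl or a chain ending in a carboxylic acid on the oxygen would match hydrogen. Nothing at hand offers an explanation for any of these steps.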